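The source may hold more compounds than are shown below. What is called first, only, known or untested is meant among the compounds shown, and "the series" means these compounds.

Measured in an assay on isolated protein for displacement of a labelled ligand from melanin-concentrating hormone receptor 1 (Homo sapiens); on this read-out lower numbers stand for stronger inhibition and higher numbers for weaker inhibition:
compound 1 `CCCN(CCC)c1ccc2cc(NC(=O)CCc3ccc(C(F)(F)F)cc3)ccc2n1`: 490 nM
compound 2 `O=C(CCCCCCCCCCCCc1ccc(C(F)(F)F)cc1)Nc1ccc2nc([N+]34CCC(CC3)CC4)ccc2c1`: 5 nM
compound 3 `CCCc1cc(N(C)C)c2cc(NC(=O)CCc3ccc(C(F)(F)F)cc3)ccc2n1`: 12 nM

Compound 1 gives the highest number of the three in this assay; compound 3 and compound 2 both lie lower by margins beyond the scatter, so compound 1 is the weakest of the measured set. Compound 4 `NC1CCN(c2ccc3cc(NC(=O)CCc4ccc(C(F)(F)F)cc4)ccc3n2)C1` has not been measured. It differs from compound 1 in one place: 3-aminopyrrolidin-1-yl in place of dipropylamino on an aromatic carbon. Going by the values given here, no measured pair isolates this change, so its size rests on the spread among the three measured values. Since compound 3 gives 12 nM and compound 2 gives 5 nM, a move toward lower numbers is expected, and the step from compound 1 to compound 4 is estimated at a 12-fold lower number from compound 1 to compound 4 (1.09 log units; beyond the scatter), beyond the scatter. Compound 4 is expected near 40 nM, within 6 nM to 250 nM.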

Compound 4, half-maximal inhibitory concentration: 12 nM
The estimate for compound 4 lay 3.3-fold (0.52 log units) above the measured number; the range from low to high includes it.
By their numbers in this assay, from the lowest: compound 2; then compounds 3 and 4 (each within the scatter of the next); then compound 1.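

In this assay, 3-aminopyrrolidin-1-yl in place of dipropylamino on the aromatic carbon next to the ring nitrogen gives a 41-fold lower number from compound 1 to compound 4 (1.61 log units; beyond the scatter) as a single change. Going by these compounds alone, this position therefore responds strongly to the group it carries, which the earlier compounds, differing in more than one place, could not isolate. No evidence on the origin of this step is at hand.

The compounds shown leave open whether the ring or its amino group accounts for the step; plain pyrrolidin-1-yl on this carbon would separate the two. As far as these compounds go, how a morpholine ring would compare also stays open.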